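Lengthening the chain on the nitrogen of a shared core

A few compounds are considered here, and "the series" means these few. Any claim that something is new, unique, unknown or untested is made for them only; others in the source may bear on it.

Of the compounds shown here, three on a shared core have been measured in an assay on isolated protein (urine) for inhibition of Myeloperoxidase (Homo sapiens), read by spectrophotometry; on this read-out higher numbers stand for weaker inhibition and lower numbers for stronger inhibition. Compound 1 `CCCCCn1nc2ccccc2c1OC`, which carries a methoxy group and a pentyl chain, gives 3880 nM. Compound 2 `CC(C)n1[nH]c2ccccc2c1=O`, with an isopropyl group and a ring oxo group, gives 660 nM. Compound 3 `CCCCn1[nH]c2ccccc2c1=O`, in which butyl takes the place of isopropyl, gives 792 nM, the second highest of the three numbers; its nearest neighbour is compound 2, and compound 1 lies furthest away. The step of a 1.2-fold higher number from compound 2 to compound 3 (0.08 log units; within the scatter) shows that swapping these two small alkyl groups on the aromatic nitrogen left the number essentially where it was.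

Compound 4 `CCCCCCCCn1[nH]c2ccccc2c1=O` differs from compound 3 by the change (butyl in place of hydrogen on a saturated chain carbon, four bonds along the chain from an aromatic nitrogen). Going by the values given here, the only step that bears on this change is the one from compound 2 to compound 3, which was within the scatter, and it concerns shorter chains than the one that now enters. Compound 1 cannot be compared directly, as it differs in more than one place. As far as these compounds go, on this evidence the expectation for compound 4 is a step of a 1.1-fold higher number from compound 3 to compound 4 (0.06 log units; within the scatter) that does not clearly exceed the scatter, though a longer chain is untested here, so the range is kept wide. Compound 4 is therefore estimated at 900 nM, between 300 nM and 3000 nM.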

Compound 4, half-maximal inhibitory concentration: > 10000 nM
Compound 4 gave a limit, no number; the forecaster's own chance of this, stated with the estimate: 5%; middle value at least 11-fold (1.04 log units) from the limit.
By their numbers in this assay, from the lowest: compounds 2 and 3 (each within the scatter of the next); then compound 1. At a limit, above all of these: compound 4.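

The earlier pair showed only that isopropyl and butyl on the aromatic nitrogen gave numbers within the scatter of each other, which said nothing about a chain reaching further out. At the place four bonds along the chain from an aromatic nitrogen, the change is not neutral: butyl in place of hydrogen there gives an at least 12-fold higher number from compound 3 to compound 4 (1.10 log units; beyond the scatter), a large step that marks the longer chain of compound 4 as clearly weaker in inhibition than compound 3. In this assay the reading for compound 4 is a limit and not a number, so this step has a floor but no measured size: the limit of > 10000 nM in this assay, at which 1 of the 4 values shown sits.

Where along the chain the number starts to rise stays open, as does whether a hexyl chain on the shared core would read like compound 3 or like compound 4, and compound 1, which differs from these in more than one place, cannot settle this. Also open, as far as these compounds go, is whether a chain of this length bearing an amine or a carboxylic acid would give a measurable number.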